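A few compounds are considered here, and "the series" means these few. Any claim that something is new, unique, unknown or untested is made for them only; others in the source may bear on it.

compound 1 `c1ccc(C2OOC3CCCC(c4ccccc4)(OO2)O3)cc1`: 50000 nM
compound 2 `CC(C)(C)C1OOC2CCCC(c3ccccc3)(OO1)O2`: 26000 nM
compound 3 `Fc1ccc(C2OOC3CCCC(c4ccccc4)(OO2)O3)cc1`: not yet measured

In a functional assay on FM3A cells (Mus musculus) for cytotoxicity (a lower number here means that less compound is needed, a higher number that more compound is needed for the effect), compound 2 gives 26000 nM, within the scatter of compound 1. The next change puts 4-fluorophenyl in place of tert-butyl on a saturated ring carbon. For the measured compounds named here, the only measured step that bears on it is a 1.9-fold lower number from compound 1 to compound 2 (0.28 log units; within the scatter), which exchanges phenyl and tert-butyl and stays within the scatter. Going by the values given here, no measured compound carries 4-fluorophenyl. The expected change in this assay is therefore small, a 1.5-fold higher number from compound 2 to compound 3 (0.19 log units; within the scatter), with nothing expected beyond the scatter. For compound 3 the estimate is 40000 nM, with an expected range of 15000 nM to 90000 nM.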

Compound 3, half-maximal effective concentration: 17000 nM
Estimate against measurement, compound 3: 2.4-fold (0.37 log units) above; the measured number falls inside the stated range.
By their numbers in this assay, from the lowest: compounds 3, 2 and 1 (each within the scatter of the next, the first and the last beyond it).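

In this assay the exchange of tert-butyl for 4-fluorophenyl on the saturated ring carbon gives a 1.5-fold lower number from compound 2 to compound 3 (0.18 log units; within the scatter) and does not separate these two groups. Fluoro in place of hydrogen on the aromatic carbon gives a 2.9-fold lower number from compound 1 to compound 3 (0.47 log units; beyond the scatter) as the first step in the series beyond the scatter, though only a modest one. Nothing on hand explains this step. From the compounds shown here alone, whether chloro, methoxy or an amine in place of that fluoro would go further remains open. Also open, going by these compounds, is how the number responds to a carboxylic acid or a longer chain on the saturated ring carbon.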